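The compounds below may be only part of what the source reports. "The series", "measured", "known", "first", "only" and "open" are said of these compounds alone.

Among the compounds with values here, compound 3 `Cn1c(=O)c(=O)n(C2CCCC2)c2nc(N/N=C/c3ccc(F)c(Cl)c3)ncc21` gives 8550 nM in a functional assay on PC-3 cells (Homo sapiens) for antiproliferative activity, read by MTT assay (on this read-out lower numbers stand for stronger inhibition and higher numbers for weaker inhibition), and so holds the lowest number of the three measured so far. Compound 1 `Cn1c(=O)c(=O)n(C2CCCC2)c2nc(N/N=C/c3ccccc3)ncc21` gives 48200 nM, and compound 2 `Cc1cccc(/C=N/Nc2ncc3c(n2)n(C2CCCC2)c(=O)c(=O)n3C)c1` gives 53600 nM; the step of a 1.1-fold higher number from compound 1 to compound 2 (0.05 log units; within the scatter) is within the scatter, so those two stand level. The steps of a 5.6-fold lower number from compound 1 to compound 3 (0.75 log units; beyond the scatter) and a 6.3-fold lower number from compound 2 to compound 3 (0.80 log units; beyond the scatter) are the only ones beyond the scatter, both reached by exchanging the aryl on the carbon with a double bond to nitrogen.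

Compound 4 `Cn1c(=O)c(=O)n(C2CCCC2)c2nc(N/N=C/c3ccc(S(C)(=O)=O)cc3)ncc21` carries the change (4-(methylsulfonyl)phenyl in place of 3-chloro-4-fluorophenyl on a carbon with a double bond to nitrogen). Within the data shown here, no measured step covers a methylsulfonyl group, so the gain seen for compound 3 gives no direct precedent here; the two steps that bear on it show only that the aryl in this position shifts the number by modest amounts, and that the plain phenyl of compound 1 and the 3-methylphenyl of compound 2 sit together. The expectation is therefore that the number of compound 4 moves back up toward the range of compound 1 and compound 2 rather than further down, by the step of a 2.9-fold higher number from compound 3 to compound 4 (0.47 log units; beyond the scatter) beyond the scatter. For compound 4 in this assay the estimate is 25000 nM, within a range of 6000 nM to 90000 nM.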

Compound 4, half-maximal inhibitory concentration: 26600 nM
Compound 4: the middle estimate sits 1.1-fold (0.03 log units) below what was measured; measured number inside the range.
By their numbers in this assay, from the lowest: compound 3; then compounds 4, 1 and 2 (each within the scatter of the next).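

In this assay, the 4-(methylsulfonyl)phenyl group on the carbon with a double bond to nitrogen does not reproduce the result of the 3-chloro-4-fluorophenyl group (a 3.1-fold higher number from compound 3 to compound 4 (0.49 log units; beyond the scatter)), so the position does not accept every substituted aryl equally. Compound 4 stands level with both less substituted aryl compounds (a 1.8-fold lower number from compound 1 to compound 4 (0.26 log units; within the scatter); a 2.0-fold lower number from compound 2 to compound 4 (0.30 log units; within the scatter)), which leaves compound 3 as the only one of the four set apart beyond the scatter, while methylsulfonyl in place of hydrogen gives no readable change from the plain phenyl. No measurement on these compounds accounts for the separation of compound 3 from the other three.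

The compounds shown leave open whether the gain of compound 3 depends on the chlorine, the fluorine or the two together, as no phenyl here carries only one of these halogens. Also open, on these data alone, is how this position responds to an amine or a carboxylic acid on the aryl ring, and how any change to the shared core, which is constant across all four compounds, would read in this assay.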